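Quinoxaline for benzoxazole on the piperazine amide series

The source may hold more compounds than are shown below. What is called first, only, known or untested is meant among the compounds shown, and "the series" means these compounds.

Two compounds of this set have a number in an assay on isolated protein for binding affinity to somatostatin receptor type 3 (Homo sapiens); a lower number here means tighter binding, a higher number weaker binding. Compound 1 `COC(=O)c1cc(CC(C)CN2C[C@@H]3CCCC[C@@H]3[C@H](C(=O)N3CCN(c4ccc([N+](=O)[O-])cc4)CC3)C2)cc(C(=O)OC)c1` gives 1.35 nM in this assay. Compound 2 `Cc1nc2cc(C[C@H](C)CN3C[C@@H]4CCCC[C@@H]4[C@H](C(=O)N4CCN(c5ccc(F)c(F)c5)CC4)C3)ccc2o1` gives 3.39 nM in this assay, and this is the higher of the two numbers: compound 1 sits a clear step below, beyond the usual scatter. Compound 3 `C[C@@H](Cc1ccc2nccnc2c1)CN1C[C@@H]2CCCC[C@@H]2[C@H](C(=O)N2CCN(c3ccc(F)c(F)c3)CC2)C1` has not yet been measured. It differs from compound 2 in one place: quinoxalin-6-yl in place of 2-methyl-1,3-benzoxazol-5-yl on a saturated chain carbon, three bonds along the chain from an amine nitrogen in a ring. Among the compounds with values here, no measured pair in this set shows that change, so its effect is unknown; both groups carry the same count of acceptors and heavy atoms, as the difference above shows. Compound 3 is therefore expected to stay close to compound 2, with a step of a 1.0-fold higher number from compound 2 to compound 3 (0.01 log units; within the scatter) not beyond the scatter in either direction. The estimate for compound 3 in this assay is 3.5 nM, with a range from 1.2 nM to 10 nM.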

Compound 3, dissociation constant: 10.7 nM
Beside the measured number, compound 3's estimate is 3.1-fold (0.49 log units) below it; the measured number lies above the stated range.
By their numbers in this assay, from the lowest: compound 1; then compound 2; then compound 3.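

In this assay the change from 2-methyl-1,3-benzoxazol-5-yl to quinoxalin-6-yl gives a 3.2-fold higher number from compound 2 to compound 3 (0.50 log units; beyond the scatter) and so shows that this position, on a saturated chain carbon, three bonds along the chain from an amine nitrogen in a ring, responds to the identity of the group it carries. The two groups have the same counts of heavy atoms and hydrogen-bond acceptors, so those counts alone do not make them interchangeable here. Nothing available accounts for this difference.

Within the data shown here, with only this one pair, it remains open whether the loss follows from leaving the benzoxazole or from entering the quinoxaline. As far as these compounds go, a quinolin-6-yl or a plain phenyl group at this position would help separate the two, and whether the step holds with other piperazine aryl groups also remains open.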